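The source may report more compounds than this note shows. Statements on the series, on what has been measured and on what is new or still open speak of the compounds shown alone.

The three compounds already tested share one core, and each carries a different group on the nitrogen of that core. Compound 1 `Cc1cc(C(C)C)ccc1OC(c1ccc(Cl)cc1)c1cnc(NC(=O)OC(C)(C)C)s1` was tested in an ADME assay on HepG2 2.2.15 cells (Homo sapiens) for cytotoxicity (on this read-out higher numbers stand for lower toxicity in this test and lower numbers for higher toxicity in this test), and there compound 1 gives > 50000 nM, a limit of the assay rather than a number. Compound 2 `CC(C)(C)OC(=O)Nc1ncc(C(Oc2ccc(Cc3ccccc3)cc2)c2ccc(Cl)cc2)s1` likewise reaches only a limit in this assay, where compound 2 gives > 50000 nM. Compound 3 `Clc1ccc(C(Oc2ccc3cc(Br)ccc3c2)c2cnc(NCC3CCCCC3)s2)cc1` is reported in this assay without a number at all: compound 3 is described as "not toxic" (no number reported). Compound 3 therefore cannot be placed on a scale; what surrounds it is the limit of > 50000 nM in this assay, at which 2 of the 3 values shown sit, and the description of compound 3 reads in the same sense.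

Compound 4 `O=C(Nc1ncc(C(Oc2ccc3cc(Br)ccc3c2)c2ccc(Cl)cc2)s1)c1cc(F)c(F)cc1F` is the one not yet measured. It differs from compound 3 only at the nitrogen on the aromatic ring: (2,4,5-trifluorophenyl)carbonyl in place of cyclohexylmethyl on a nitrogen on an aromatic ring. Going by the values given here, no step between measured compounds with a number exists, so no size of step can be read from the data; with all three known values at or beyond the limit, no change beyond the usual scatter is expected in either direction. Compound 4 is expected to give 50000 nM in this assay, within the range 20000 nM to 100000 nM, most likely again as a limit rather than a number.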

Compound 4, half-maximal cytotoxic concentration: "not toxic" (no number reported)
For compound 4 the study gives words and no number, and the estimate cannot be compared.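

In this assay, compound 3 and compound 4 are both described only in words, as "not toxic", so no step can be read between them. The compounds shown leave open where any of them would fall on a numerical scale, and the only values given stop at a limit: the limit of > 50000 nM in this assay, at which 2 of the 4 values shown sit.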